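Working notes: the step from compound 1 to compound 4

The compounds below may be only part of what the source reports. "The series", "measured", "known", "first", "only" and "open" are said of these compounds alone.

Compound 1 `O=C(NNc1ccc(F)cc1)c1ccc(NS(=O)(=O)c2cnc(O)nc2O)cc1` is the starting point here. In a functional assay on SGC-7901 cells (Homo sapiens) for antiproliferative activity, read by MTT assay, with a stated time of 24 h (on this read-out higher numbers stand for weaker inhibition and lower numbers for stronger inhibition), compound 1 gives > 20000 nM as its result, which is a limit and not a number. In this assay compound 2 `Cc1ccccc1NNC(=O)c1ccccc1NS(=O)(=O)c1cnc(O)nc1O` gives > 20000 nM as its result, again a limit. In this assay compound 3 `Cc1cccc(NNC(=O)c2ccccc2NS(=O)(=O)c2cnc(O)nc2O)c1` gives > 20000 nM as its result, also a limit. Among the measured compounds shown here, the series so far therefore sits at the limit of > 20000 nM in this assay, at which 3 of the 3 values shown sit, and offers no numerical value to build on.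

Compound 4 `O=C(NNC(=O)c1ccccc1F)c1ccc(NS(=O)(=O)c2cnc(O)nc2O)cc1` carries the change (2-fluorophenyl)carbonyl in place of 4-fluorophenyl on an amine nitrogen with (2-fluorophenyl)carbonyl in place of 4-fluorophenyl on an amine nitrogen. For the measured compounds named here, the only measured step is a step that the two limits leave unreadable from compound 2 to compound 3 and it involves a different change, 3-methylphenyl in place of 2-methylphenyl, so it provides no size to carry over. Going by the values given here, no measured step swaps an aryl group for a carbonyl-bearing group at this place.

Resting on the limit of > 20000 nM in this assay, at which 3 of the 3 values shown sit, the expected size is a number no higher from compound 1 to compound 4 (the limit leaves the size open) with no direction that the data can support, and this remains only an estimate. For compound 4 the estimated value is 20000 nM with an expected range from 6000 nM to 40000 nM and the assay may well report only a limit again.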

Compound 4, half-maximal inhibitory concentration: > 20000 nM
Compound 4: only a limit was reported; the forecaster's own chance of this, stated with the estimate: 65%; the middle value sits exactly at the limit.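

Compound 1 and compound 4 are both reported only as limits in this assay, so the step between them cannot be read and yields no size. The compounds shown leave open whether any change at this amine nitrogen, or elsewhere on the shared core, would give a numerical value, and the series stays at a single point: the limit of > 20000 nM in this assay, at which 4 of the 4 values shown sit.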